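The source may report more compounds than this note shows. Statements on the series, on what has been measured and on what is new or still open speak of the compounds shown alone.

Of the compounds shown here, three sharing one core have been measured in a functional assay on QG-56 cells (Homo sapiens) for cytotoxicity, read by MTT assay, with a stated time of 48 h; on this read-out lower numbers stand for stronger inhibition and higher numbers for weaker inhibition. Compound 1 `COc1cc(/C=C/C(=O)C2=C(/C=C/c3ccc(O)c(OC)c3)NC(=S)NC2c2ccccc2)ccc1O` gives 100000 nM, compound 2 `COc1cc(/C=C/C(=O)C2=C(/C=C/c3ccc(O)c(OC)c3)NC(=S)NC2c2ccc(C)cc2)ccc1O` gives 12500 nM, and compound 3 `COc1cc(/C=C/C(=O)C2=C(/C=C/c3ccc(O)c(OC)c3)NC(=S)NC2c2ccccc2O)ccc1O` gives 50000 nM. On these numbers compound 3 stands second highest of the three: against compound 1 the step of a 2.0-fold lower number from compound 1 to compound 3 (0.30 log units; within the scatter) stays within the scatter, while against compound 2 the step of a 4.0-fold higher number from compound 2 to compound 3 (0.60 log units; beyond the scatter) is a modest rise.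

Compound 4 `COc1cc(/C=C/C(=O)C2=C(/C=C/c3ccc(O)c(OC)c3)NC(=S)NC2c2ccc(N(C)C)cc2)ccc1O` is not yet measured. It differs from compound 3 in one place: 4-(dimethylamino)phenyl in place of 2-hydroxyphenyl on a saturated ring carbon.

Going by the values given here, two measured steps bear on this change. The step of an 8.0-fold lower number from compound 1 to compound 2 (0.90 log units; beyond the scatter) shows that a group on the distant carbon of this phenyl ring went with a clearly lower number, and the step of a 4.0-fold higher number from compound 2 to compound 3 (0.60 log units; beyond the scatter) shows that moving from 4-methylphenyl to 2-hydroxyphenyl went with a higher one. Compound 4 carries a group on that distant carbon again, so a lower number than compound 3 is expected, a step of about a 3.3-fold lower number from compound 3 to compound 4 (0.52 log units; beyond the scatter). Compound 4 is therefore estimated at 15000 nM, with a likely range from 5000 nM to 50000 nM.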

Compound 4, half-maximal inhibitory concentration: 25000 nM
Compound 4: the middle estimate sits 1.7-fold (0.22 log units) below what was measured, and the stated range covers the measured number.
By their numbers in this assay, from the lowest: compounds 2, 4, 3 and 1 (each within the scatter of the next, the first and the last beyond it).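

In this assay, the change from 2-hydroxyphenyl to 4-(dimethylamino)phenyl on this saturated ring carbon gives a 2.0-fold lower number from compound 3 to compound 4 (0.30 log units; within the scatter), and the change from methyl to dimethylamino gives a 2.0-fold higher number from compound 2 to compound 4 (0.30 log units; within the scatter), so neither swap can be told apart from repeat-measurement noise. Against the plain phenyl of compound 1, the step of a 4.0-fold lower number from compound 1 to compound 4 (0.60 log units; beyond the scatter) is beyond the scatter, which means that 4-(dimethylamino)phenyl, like 4-methylphenyl in compound 2, is now a second group at this position that goes with a lower number, while the 2-hydroxyphenyl of compound 3 stays within the scatter of compound 1. No measurement at hand explains this pattern.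

As far as these compounds go, whether a carboxylic acid or a longer chain in place of the dimethylamino group would fit the same pattern stays open. From the compounds shown here alone, it is also open how 4-hydroxyphenyl would compare with 2-hydroxyphenyl.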